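The compounds below may be only part of what the source reports. "The series", "measured", "known", "first", "only" and "open" are said of these compounds alone.

Values in a functional assay on MDA-MB-231 cells (Homo sapiens) for inhibition, read by MTT assay, with a stated time of 48 h; on this read-out lower numbers stand for stronger inhibition and higher numbers for weaker inhibition:
- compound 1 `COc1ccc(N(C)c2nc(C)nc3ccccc23)cc1C(=O)OCCC[Se]C#N`: 1180 nM
- compound 2 `COc1ccc(N(C)c2nc(C)nc3ccccc23)cc1C(=O)NCC[Se]C#N`: 1250 nM

Compound 2, at 1250 nM, cannot be separated from compound 1, at 1180 nM. The next compound to consider is compound 3 `COc1ccc(N(C)c2nc(C)nc3ccccc23)cc1[Se]C`. The change from compound 2 is a group of 2 heavy atoms (1 carbon, 1 selenium; no ring) in place of a group of 8 heavy atoms (4 carbon, 2 nitrogen, 1 oxygen, 1 selenium; no ring), on an aromatic carbon, on an aromatic carbon, ortho to a methoxy group.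

Going by the values given here, only one measured step bears on this: a 1.1-fold higher number from compound 1 to compound 2 (0.03 log units; within the scatter). It bears weakly, as it swaps one chain on a carbonyl carbon for another, whereas here the whole chain goes, carbonyl included. Among the compounds with values here, no measured compound shows the effect of removing that chain, so this assay offers no firm guide to size or direction. A tentative expectation is a 3.1-fold lower number from compound 2 to compound 3 (0.49 log units; beyond the scatter), with low confidence in the direction. For compound 3 the estimated value is 400 nM, with an expected range of 30 nM to 3000 nM.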

Compound 3, half-maximal inhibitory concentration: 10 nM
The estimate for compound 3 lay 40-fold (1.60 log units) above the measured number, and the stated range ends above it.
By their numbers in this assay, from the lowest: compound 3; then compounds 1 and 2 (each within the scatter of the next).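

At this aromatic carbon, ortho to a methoxy group, the group present matters far more than the swap between the two carbonyl-linked chains suggested: this assay gives a 130-fold lower number from compound 2 to compound 3 (2.10 log units; beyond the scatter) and a 120-fold lower number from compound 1 to compound 3 (2.07 log units; beyond the scatter). The two steps agree in direction and size, so the lower number does not depend on which of these chains leaves, but the change removes the carbonyl, the nitrile and the chain together, and no single part can be held responsible. Nothing available accounts for a step of this size.

Open, going by these compounds, is whether selenium itself is needed, which a methylthio group at this carbon would test. Also open, on these data alone, is whether the carbonyl alone is tolerated, as a methyl ester or a carboxylic acid there would show, and whether a longer alkylselenyl chain retains the low number.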